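The compounds below may be only part of what the source reports. "The series", "measured", "known", "first", "only" and "open" are said of these compounds alone.

In a functional assay on MDA-MB-231 cells (Homo sapiens) for antiproliferative activity, read by luminescence, with a stated time of 24 h (on this read-out lower numbers stand for stronger inhibition and higher numbers for weaker inhibition), compound 1 `Cc1cc(C)c2c(c1C)OC(C)(COc1ccc(/C=C3\SC(=O)NC3=O)cc1)CC2` gives 10800 nM. Compound 3 `Cc1c(C)c2c(c(C)c1O)CCC(C)(COc1ccc(/C=C3\SC(=O)NC3=O)cc1)O2` gives 16600 nM, and the two sit together, with a 1.5-fold higher number from compound 1 to compound 3 (0.19 log units; within the scatter). Compound 1 therefore stands level with compound 3 on the numbers available. For compound 2 `CC(=O)NCCNC(=O)CCC(=O)Oc1c(C)c(C)c2c(c1C)CCC(C)(COc1ccc(/C=C3\SC(=O)NC3=O)cc1)O2`, the assay reports only a limit, > 25000 nM.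

Compound 4 `Cc1cc(C)c2c(c1C)OC(C)(COc1ccc(CC3SC(=O)NC3=O)cc1)CC2` keeps the core of compound 1 and changes the group on the aromatic carbon para to a large group: a group of 8 heavy atoms (4 carbon, 1 nitrogen, 2 oxygen, 1 sulfur; one five-membered non-aromatic ring with 2 hetero atoms) in place of a group of 8 heavy atoms (4 carbon, 1 nitrogen, 2 oxygen, 1 sulfur; one five-membered non-aromatic ring with 2 hetero atoms), on an aromatic carbon. The entering group is (2,4-dioxo-1,3-thiazolidin-5-yl)methyl, and the count of double bonds outside aromatic rings is the main thing that differs. Within the data shown here, no measured step covers this change. Among the measured compounds shown here, the nearest evidence is the single step of hydroxy in place of hydrogen on an aromatic carbon, at another place in the molecule, and that step, a 1.5-fold higher number from compound 1 to compound 3 (0.19 log units; within the scatter), gives no sign of a large shift. No step beyond the scatter is therefore expected in this assay, and the expected step is a 1.1-fold higher number from compound 1 to compound 4 (0.05 log units; within the scatter). For compound 4, the estimated value is 12000 nM, with an expected range from 5500 nM to 25000 nM.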

Compound 4, half-maximal inhibitory concentration: 12300 nM
Compound 4: the middle estimate sits 1.0-fold (0.01 log units) below what was measured, and the stated range covers the measured number.
By their numbers in this assay, from the lowest: compounds 1, 4 and 3 (each within the scatter of the next). At a limit, above all of these: compound 2.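

At the aromatic carbon para to a large group, the (2,4-dioxo-1,3-thiazolidin-5-yl)methyl group has 2 double bonds outside aromatic rings where the group it replaces has 3, and in this assay this gives a 1.1-fold higher number from compound 1 to compound 4 (0.06 log units; within the scatter). Among these compounds, until this result, the only readable step was hydroxy in place of hydrogen at another place in the molecule, so this is the first evidence that this second place can also be changed with no step beyond the scatter. No measurement shown bears on why this step stays within the scatter.

The compounds shown leave open what a group of a different make-up, such as a carboxylic acid or an amine in place of the five-membered ring, would do at this place. They also leave open whether the same change would give a similar result with the hydroxy group of compound 3 present.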